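A few compounds are considered here, and "the series" means these few. Any claim that something is new, unique, unknown or untested is made for them only; others in the source may bear on it.

Of the compounds shown here, three have so far been tested in a functional assay on H266 cells (Homo sapiens) for cytotoxicity, read by resazurin assay, with a stated time of 72 h; on this read-out lower numbers stand for stronger inhibition and higher numbers for weaker inhibition. Compound 1 `COc1cc(/C=C/C(=O)OCCCCCCO[N+](=O)[O-])ccc1O` gives > 50000 nM, which is a limit of the assay and not a number. Compound 2 `O=C(/C=C/c1ccc(O)c(O)c1)OCc1c(-c2ccccc2)no[n+]1[O-]` gives an actual number, 14200 nM. Going by these compounds, compound 3 `O=C(/C=C/c1ccc(OCCCCCCO[N+](=O)[O-])c(O)c1)OCCCCCCO[N+](=O)[O-]` gives > 50000 nM, which is again only a limit, so its exact place on the scale is unknown. The results so far are thus defined largely by the limit of > 50000 nM in this assay, at which 2 of the 3 values shown sit.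

The next compound to consider is compound 4 `COc1cc(/C=C/C(=O)OCCCCCCO[N+](=O)[O-])ccc1OCCCCCCO[N+](=O)[O-]`. It differs from compound 3 in one place, with methyl in place of hydrogen on an oxygen on an aromatic ring, so that a hydroxy becomes a methoxy: methyl in place of hydrogen on an oxygen on an aromatic ring. Among the compounds with values here, no measured pair in this small set shows the size of such a change, so the expectation here is a judgement rather than a read-across. The starting point for that judgement is compound 3 with > 50000 nM, a limit and not an exact value. The expected a number no higher from compound 3 to compound 4 (the limit leaves the size open) is no shift in either direction beyond the usual scatter, and the assay may well report only a limit again. For compound 4, the estimated half-maximal inhibitory concentration is 50000 nM, with an expected range of 25000 nM to 100000 nM.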

Compound 4, half-maximal inhibitory concentration: > 50000 nM
Compound 4: only a limit was reported (the forecaster's own chance of this, stated with the estimate: 85%); the middle value sits exactly at the limit.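

Compound 4 gives > 50000 nM, which is a limit of the assay and not a number. Its steps from compound 3 and from compound 1, which also stand at limits, cannot be read. The compounds shown leave open whether either of these two changes alters cytotoxicity at all, and one limit still marks the results: the limit of > 50000 nM in this assay, at which 3 of the 4 values shown sit.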